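Notes on the 4-methoxyphenyl to phenyl step

The compounds below may be only part of what the source reports. "The series", "measured", "known", "first", "only" and "open" are said of these compounds alone.

Measured compounds:
compound 1 `C=C1C[C@]23C[C@@]1(O)CC[C@@H]2c1cccc(C)c1[C@@H]3Cn1cc(-c2ccc(C)cc2)nn1`: > 20000 nM
compound 2 `COc1ccc(-c2cn(C[C@H]3c4c(ccc(O)c4C)[C@@H]4CC[C@@]5(C)C[C@]43CC5=O)nn2)cc1`: > 20000 nM

In a functional assay on MCF7 cells (Homo sapiens) for cytotoxicity, read by MTT assay, with a stated time of 4 days (on this read-out lower numbers stand for stronger inhibition and higher numbers for weaker inhibition), compound 1 gives > 20000 nM, which is a limit of the assay and not a number. Compound 2 gives > 20000 nM in this assay, again a limit. Both values sit at the limit of > 20000 nM in this assay, at which 2 of the 2 values shown sit; compound 2 therefore stands at the limit, with no number to compare against.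

Compound 3 `Cc1c(O)ccc2c1[C@H](Cn1cc(-c3ccccc3)nn1)[C@@]13CC(=O)[C@@](C)(CC[C@@H]21)C3` is the next compound; it differs from compound 2 by hydrogen in place of methoxy on an aromatic carbon. Among the compounds with values here, no step between two measured compounds is known here. The step from compound 2 to compound 3 is expected to be none beyond the scatter, a step that the limit leaves unreadable from compound 2 to compound 3, with the result most likely remaining a limit. Compound 3 is estimated at 25000 nM, in the range 10000 nM to 60000 nM.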

Compound 3, half-maximal inhibitory concentration: > 20000 nM
Compound 3 was reported as a limit (the forecaster's own chance of this, stated with the estimate: 85%); the middle value does not contradict the limit.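

No step can be read from compound 2 to compound 3, as both values are limits of the assay and not numbers: the limit of > 20000 nM in this assay, at which 3 of the 3 values shown sit.

In this assay the compounds shown leave open what the 4-methoxyphenyl to phenyl change does to the read-out.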